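The source may hold more compounds than are shown below. What is called first, only, known or untested is meant among the compounds shown, and "the series" means these compounds.

Working notes on the series tested for antiproliferative activity in a functional assay on HUVEC cells (Homo sapiens) for antiproliferative activity, read by MTT assay, with a stated time of 24 h; a lower number here means a stronger inhibitor, a higher number a weaker inhibitor. Compound 1 `C=CCc1cc(-c2ccc(OC)cc2)cc(CC=C)c1O` reaches only the assay limit, > 100000 nM. Compound 3 `C=CCc1ccc(OC(C)C)c(-c2ccc(OC(C)C)c(CC=C)c2)c1` likewise returns only the limit, > 100000 nM. Within the data shown here, compound 2 `C=CCc1cc(-c2ccc(C(F)(F)F)cc2)ccc1O` is the one member with an actual number, 74000 nM in this assay, and so stands alone among the values shown. Compound 4 `C=CCc1cc(-c2ccccc2)ccc1O` differs from compound 2 by hydrogen in place of trifluoromethyl on an aromatic carbon. Among the measured compounds shown here, no step between two measured compounds is available, so the effect of this change is untested here; the expected step is small and toward weaker inhibition, a 1.5-fold higher number from compound 2 to compound 4 (0.17 log units; within the scatter). Compound 4 is therefore expected near 110000 nM, between 40000 nM and 300000 nM, with a real chance that only a limit is reported because of the limit of > 100000 nM in this assay, at which 2 of the 3 values shown sit.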

Compound 4, half-maximal inhibitory concentration: > 100000 nM
Compound 4: only a limit was reported; the forecaster's own chance of this, stated with the estimate: 50%; the middle value is on the limit's open side.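

Among these compounds, this is the first one-place comparison, with hydrogen in place of trifluoromethyl on an aromatic carbon, para to a large group, and in this assay it gives an at least 1.3-fold higher number from compound 2 to compound 4 (0.13 log units; that floor lies within the scatter). Compound 4 gives only a limit, > 100000 nM. As far as these compounds go, the step is thus a floor, and the true size of the change at this position remains unknown.

Open, from the compounds shown here alone, is how an amine or a carboxylic acid at this position would compare with compound 2, at 74000 nM. Also open, going by these compounds, is whether trifluoromethyl would give a measurable number on the core of compound 1.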